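Chlorine moved across the aryl ring on the piperazine

The source may report more compounds than this note shows. Statements on the series, on what has been measured and on what is new or still open speak of the compounds shown alone.

The series shares one core; compound 1 `CCCc1nc(-c2ccccc2)c(CNCCCN2CCN(c3cccc(Cl)c3)CC2)o1` carries a 3-chlorophenyl on the ring amine nitrogen, compound 2 `CCCc1nc(-c2ccccc2)c(CNCCCN2CCN(c3ccc(C)cc3)CC2)o1` a 4-methylphenyl, compound 3 `CCCc1nc(-c2ccccc2)c(CNCCCN2CCN(c3ccccc3F)CC2)o1` a 2-fluorophenyl. In an assay on HEK293 cells for inhibition of Voltage-dependent T-type calcium channel subunit alpha-1G (Homo sapiens), read by patch clamp (on this read-out lower numbers stand for stronger inhibition and higher numbers for weaker inhibition), compound 1 gives 1750 nM, compound 2 gives 130000 nM, and compound 3 gives 16100 nM. Compound 3 thus stands second highest of the three, with a 9.2-fold higher number from compound 1 to compound 3 (0.96 log units; beyond the scatter) on one side and an 8.1-fold lower number from compound 2 to compound 3 (0.91 log units; beyond the scatter) on the other.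

Compound 4 `CCCc1nc(-c2ccccc2)c(CNCCCN2CCN(c3ccc(Cl)cc3)CC2)o1` is not yet measured. The change is 4-chlorophenyl in place of 2-fluorophenyl on an amine nitrogen in a ring. For the measured compounds named here, two measured steps touch it: the step from compound 1 to compound 3 shows that chlorine at one ring position can be substantially more favourable than fluorine at another, while compound 2 shows a substituent at the 4-position of the phenyl can give a very weak number. Going by the values given here, no measured step exchanges a halogen at the 4-position directly.

Taking both into account, a step of a 1.8-fold lower number from compound 3 to compound 4 (0.25 log units; within the scatter) in this assay is expected, within a broad band. Compound 4 is therefore estimated at 9000 nM, with a range of 1500 nM to 50000 nM.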

Compound 4, half-maximal inhibitory concentration: 1310 nM
The estimate for compound 4 lay 6.9-fold (0.84 log units) above the measured number, outside the stated range (below it).
By their numbers in this assay, from the lowest: compounds 4 and 1 (each within the scatter of the next); then compound 3; then compound 2.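

In this assay, the 4-position of the aryl group on the ring amine nitrogen is not unfavourable in itself: swapping methyl for chloro there gives a 99-fold lower number from compound 2 to compound 4 (2.00 log units; beyond the scatter), so the high number of the 4-methylphenyl compound goes with the methyl group and not with the position alone. Moving the chlorine leaves no measurable separation, with a 1.3-fold lower number from compound 1 to compound 4 (0.13 log units; within the scatter), so 3-chlorophenyl and 4-chlorophenyl cannot be ranked on these data and both chlorinated compounds sit well clear of the other two. Replacing the 2-fluorophenyl gives a 12-fold lower number from compound 3 to compound 4 (1.09 log units; beyond the scatter), but this step changes the halogen and its ring position together, so it cannot assign the gain to either one.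

A 2-chlorophenyl and a 4-fluorophenyl would separate the halogen from its ring position, while a 4-bromophenyl or a 4-methoxyphenyl would test how far the 4-position accepts groups other than chlorine. The compounds shown offer no measurement that explains why chloro and methyl differ so widely at this position.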